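Swapping the aryl group on the ring nitrogen

The source may hold more compounds than are shown below. What is called first, only, known or untested is meant among the compounds shown, and "the series" means these compounds.

Compound 2 `Oc1cc(C(F)(F)F)ccc1-c1nc(-c2ccccc2O)n(-c2ccc(OC(F)(F)F)cc2)n1` is the stronger of the two measured compounds in a functional assay on PC-12 cells (Rattus norvegicus) for cytotoxicity, read by MTT assay, with stated times of 2 h and 24 h, tested at 10 uM (a higher number here means a stronger effect of the compound at the concentration tested, a lower number a weaker effect), where compound 2 gives 92.5%. Going by the values given here, its nearest neighbour is compound 1 `CC(C)(C)c1ccc(-n2nc(-c3ccc(C(F)(F)F)cc3O)nc2-c2ccccc2O)cc1`, which in this assay gives 81.1%; the one measured step, a number 11.4 percentage points higher from compound 1 to compound 2 (beyond the scatter), is a modest gain that lies beyond the scatter.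

Compound 3 `Cc1ccc(-n2nc(-c3ccc(C(F)(F)F)cc3O)nc2-c2ccccc2O)c(C)c1` differs from compound 2 in the same region of the molecule: 2,4-dimethylphenyl in place of 4-(trifluoromethoxy)phenyl on an aromatic nitrogen. Among the compounds with values here, only the step from compound 1 to compound 2 bears on this, since it also changes a group carried by the aryl ring on that aromatic nitrogen, and it moved the read-out by a number 11.4 percentage points higher from compound 1 to compound 2 (beyond the scatter). That single step shows the read-out is sensitive to this part of the molecule, but the 2,4-dimethylphenyl group entering here has not been tried on any measured compound, so the direction is uncertain.

On balance a small change, likely downward from compound 2 and possibly within the scatter, is expected, so for compound 3 the estimate is 82%, with a range from 65% to 95%, which means an expected step of a number 10.5 percentage points lower from compound 2 to compound 3 (beyond the scatter).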

Compound 3, a percentage reported as activity, at one concentration (the size of the read-out at that concentration, not a potency): 106%
The estimate for compound 3 lay 24 percentage points below the measured number; the whole stated range lies below it.
By their numbers in this assay, from the lowest: compound 1; then compound 2; then compound 3.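

In this assay, the change to 2,4-dimethylphenyl on the aromatic nitrogen gives a number 13.5 percentage points higher from compound 2 to compound 3 (beyond the scatter) and, set against the 4-(tert-butyl)phenyl group, a number 24.9 percentage points higher from compound 1 to compound 3 (beyond the scatter) as well. The earlier step could have pointed to the oxygen and fluorine atoms of 4-(trifluoromethoxy)phenyl as what raises the read-out, but the entering group holds only carbon and has fewer heavy atoms, and the number still climbs, so a high read-out here does not require those atoms. No measurement shown explains why the read-out moves with the group at this place.

The 2,4-dimethylphenyl group carries two methyl groups at once, so the compounds shown cannot say whether one of them alone accounts for the rise, a question that 2-methylphenyl and 4-methylphenyl would separate. Also open, on these data alone, is how the read-out would respond to an unsubstituted phenyl or to an aryl ring carrying an amine or a carboxylic acid in this same place.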